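A Fluorobenzyl Amide in Place of the Propyl Amide

This account rests on a few compounds, and the source may have more. Where it says the series, first, only, none or still open, it means among the compounds named here.

compound 1 `C=CC1=C(C(=O)NCCC)C(c2ccc(F)cc2)OC1` — > 100000 nM
compound 2 `C=CC1=C(C(=O)O)C(c2ccc(F)cc2)OC1` — 67400 nM
compound 3 `C=CC1=C(C(=O)O)C(c2ccc(OC)cc2)OC1` — 44300 nM

In a functional assay on HeLa cells (Homo sapiens) for cytotoxicity, read by MTT assay, with a stated time of 24 h (on this read-out lower numbers stand for stronger inhibition and higher numbers for weaker inhibition), compound 1 gives only a limit, > 100000 nM. That limit is the limit of > 100000 nM in this assay, at which 1 of the 3 values shown sits. Compound 2 gives 67400 nM in this assay, and compound 3 gives 44300 nM. Both measured steps are small: an at least 1.4-fold lower number from compound 1 to compound 2 (0.17 log units; that floor lies within the scatter) and a 1.5-fold lower number from compound 2 to compound 3 (0.18 log units; within the scatter). Compound 4 `C=CC1=C(C(=O)NCc2ccccc2F)C(c2ccc(F)cc2)OC1` differs from compound 1 by 2-fluorophenyl in place of ethyl on a saturated chain carbon bound to an amide-type nitrogen. Among the compounds with values here, no measured step alters the amide chain in this way; the nearest, an at least 1.4-fold lower number from compound 1 to compound 2 (0.17 log units; that floor lies within the scatter), removes the propylamino group altogether and still stays within the scatter. A step beyond the scatter is therefore not expected, and a limit may again be reported. Compound 4 is estimated at 100000 nM, with a range from 30000 nM to 300000 nM. The expected step, a number no higher from compound 1 to compound 4 (the limit leaves the size open), lies within the scatter.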

Compound 4, half-maximal inhibitory concentration: > 100000 nM
Compound 4 ended at the assay's limit; the forecaster's own chance of this, stated with the estimate: 60%; the middle value lies on the limit itself.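

Within the data shown here, the results for compound 1 and compound 4 are both limits, so no step between them can be read: the limit of > 100000 nM in this assay, at which 2 of the 4 values shown sit. On these data alone, whether 2-fluorobenzyl in place of propyl changes the number in this assay stays open.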